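Swapping a para chloro for a methyl on a weak compound

The source may hold more compounds than are shown below. What is called first, only, known or untested is meant among the compounds shown, and "the series" means these compounds.

Compound 2 `N#Cc1c(Nc2ccccc2F)nc(SCc2cn(Cc3ccc(Cl)cc3)nn2)nc1-c1ccccc1` is the weaker of the two compounds measured in a functional assay on MGC-803 cells (Homo sapiens) for inhibition, read by MTT assay, with a stated time of 72 h; a lower number here means a stronger inhibitor, a higher number a weaker inhibitor. Its result is a limit of the assay and not a number: compound 2 gives > 64000 nM. Compound 1 `N#Cc1c(Nc2ccccc2F)nc(SCc2cn(Cc3ccccc3Cl)nn2)nc1-c1ccccc1` carries a 2-chlorophenyl where compound 2 carries a 4-chlorophenyl on a saturated chain carbon bound to an aromatic nitrogen. In this assay compound 1 gives 7580 nM, so the step of an at least 8.4-fold higher number from compound 1 to compound 2 (0.92 log units; beyond the scatter) runs to a limit, as the limit of > 64000 nM in this assay, at which 1 of the 2 values shown sits, records. Compound 3 `Cc1ccc(Cn2cc(CSc3nc(Nc4ccccc4F)c(C#N)c(-c4ccccc4)n3)nn2)cc1` keeps the shared core of compound 2 and changes only the group on the outer ring: methyl in place of chloro on an aromatic carbon. No measured step here touches this methyl-for-chloro exchange, so nothing among the numbers shown points to a direction for it; the only measured step concerns where the chloro sits, not what replaces it. With compound 2 already at the limit, compound 3 is expected to stay weak, and the expected step that the limit leaves unreadable from compound 2 to compound 3 is treated as none beyond the scatter. Compound 3 is therefore estimated at 70000 nM, with a range from 20000 nM to 250000 nM.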

Compound 3, half-maximal inhibitory concentration: 22900 nM
The estimate for compound 3 lay 3.1-fold (0.49 log units) above the measured number; the measured number falls inside the stated range.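

Exchanging chloro for methyl on the outer ring, para to a large group, moves the result off the limit of this assay, with an at least 2.7-fold lower number from compound 2 to compound 3 (0.44 log units; beyond the scatter). Compound 2 stands at a limit of the assay and not at a number: the limit of > 64000 nM in this assay, at which 1 of the 3 values shown sits. The group at this place therefore matters, since a swap of one heavy atom for another gives a readable change, yet the 4-methylphenyl of compound 3 still falls short of the 2-chlorophenyl of compound 1, with a 3.0-fold higher number from compound 1 to compound 3 (0.48 log units; beyond the scatter).

Only chloro and methyl are seen at this place, so a single exchange cannot show what feature of the group drives the difference, nor whether a methoxy group or an amine there would give a lower or a higher number. Going by these compounds, the full size of the change from compound 2 also stays unknown, as that compound has only a limit, and the measured compounds do not show whether methyl would do better or worse than chloro on the 2-substituted ring of compound 1.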